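Removing One Methoxy Group from Compound 3

A few compounds are considered here, and "the series" means these few. Any claim that something is new, unique, unknown or untested is made for them only; others in the source may bear on it.

In a functional assay for inhibition, with Homo sapiens as the target (a lower number here means a stronger inhibitor, a higher number a weaker inhibitor), compound 3 `COc1cccc(OC)c1C(=O)/C=C/c1ccccc1` gives 1150 nM. Two related structures have also been measured: compound 2 `COc1cccc(C(=O)/C=C/c2ccccc2)c1OC` gives 1670 nM, and compound 1 `COc1cc(OC)c(C(=O)/C=C/c2ccc3ccccc3c2)c(OC)c1` gives 2150 nM. These three values lie within the usual scatter of repeated measurements, so the data cannot rank the compounds despite their different structures.

The next structure, compound 4 `COc1ccccc1C(=O)/C=C/c1ccccc1`, has not been measured yet. It differs from compound 3 in one place: hydrogen in place of methoxy on an aromatic carbon. Put simply, hydrogen replaces methoxy on an aromatic carbon, ortho to a large group and meta to a methoxy group.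

Among the compounds with values here, no measured pair differs in only one place, so there is no direct example of this swap to learn from. Within the data shown here, the only guide is the narrow spread of values so far. Compound 3 at 1150 nM and compound 1 at 2150 nM stay within the scatter of each other, which gives no reason to expect a large jump. The estimated change a 1.7-fold higher number from compound 3 to compound 4 (0.22 log units; within the scatter) is therefore a small one, tentatively toward a higher number and possibly no larger than the scatter. For compound 4, the expected value is 1900 nM, with an estimated range from 700 nM to 5500 nM.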

Compound 4, half-maximal inhibitory concentration: 2230 nM
Compound 4: middle estimate off by 1.2-fold (0.07 log units), on the low side; low and high end bracket the measured number.
By their numbers in this assay, from the lowest: compounds 3, 2, 1 and 4 (each within the scatter of the next).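

In this assay, within the data shown here, putting hydrogen in place of the methoxy group that sits ortho to a large group and meta to a methoxy group gives a 1.9-fold higher number from compound 3 to compound 4 (0.29 log units; within the scatter), the first direct look at this swap. The same kind of swap, starting from compound 2 instead, gives a 1.3-fold higher number from compound 2 to compound 4 (0.13 log units; within the scatter). Neither step stands clear of the scatter, so at this level of precision, a second methoxy group on this ring cannot be told apart from hydrogen, whichever of the two compounds is the starting point. Nothing measured here speaks to what lies behind these numbers.

Going by these compounds, only methoxy and hydrogen are compared at this position, so it remains open whether a hydroxyl group, an amine, a carboxylic acid or a longer chain such as ethoxy would also stay within the scatter. On these data alone, it is equally open what happens when the last methoxy group of compound 4 is replaced by hydrogen, or when a methoxy group is replaced by hydrogen on the core of compound 1.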